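The compounds below may be only part of what the source reports. "The series", "measured", "known", "first", "only" and "open" are said of these compounds alone.

Measured in a functional assay on A549 cells (Homo sapiens) for antiproliferative activity, read by MTT assay, with a stated time of 24 h; on this read-out lower numbers stand for stronger inhibition and higher numbers for weaker inhibition:
Compound 1 `O=C(NNc1cccc(Cl)c1)c1cccc(NS(=O)(=O)c2cnc(O)nc2O)c1`: 6640 nM
Compound 2 `Cc1ccccc1NNC(=O)c1ccccc1NS(=O)(=O)c1cnc(O)nc1O`: > 20000 nM

Only compound 1 has a true number in this assay, at 6640 nM. Compound 2 stands at > 20000 nM, which is a limit of the assay and not a number. Compound 3 `O=C(NNc1ccccc1F)c1ccccc1NS(=O)(=O)c1cnc(O)nc1O` follows from compound 2 by one small exchange, fluoro in place of methyl on an aromatic carbon, ortho to a large group, so that 2-methylphenyl becomes 2-fluorophenyl: fluoro in place of methyl on an aromatic carbon. For the measured compounds named here, no measured step shows what this exchange does in this assay. From the compounds shown here alone, with that gap in mind, the expectation is for no shift beyond the scatter, and the direction stays open. The expected size is an at least 1.1-fold lower number from compound 2 to compound 3 (0.04 log units; that floor lies within the scatter). Compound 3 may well reach the same limit as compound 2. As a number, the estimate for compound 3 is 18000 nM, with an expected range from 9000 nM to 40000 nM.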

Compound 3, half-maximal inhibitory concentration: 9610 nM
Beside the measured number, compound 3's estimate is 1.9-fold (0.27 log units) above it; the measured number falls inside the stated range.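

In this assay, for the compounds shown here, fluoro in place of methyl on an aromatic carbon, ortho to a large group, gives an at least 2.0-fold lower number from compound 2 to compound 3 (0.31 log units; beyond the scatter), so this position responds to the exchange, which the earlier compounds could not show. Compound 2 stands at > 20000 nM, which is a limit of the assay and not a number. The step therefore sets only a floor, and its true size may be larger: the limit of > 20000 nM in this assay, at which 1 of the 3 values shown sits.

The compounds shown leave open whether a chloro, a methoxy or an amine on the same aromatic carbon would read like fluoro or like methyl. They also leave open whether the same exchange would have a similar effect in a compound with the other parts of the structure changed.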